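Swapping a Pyridyl Ring for a Methoxyphenol

This account rests on a few compounds, and the source may have more. Where it says the series, first, only, none or still open, it means among the compounds named here.

Compound 1 `C/C(=N\NC(=O)c1cccc(S(=O)(=O)N2CCOCC2)c1)c1cc(O)ccc1O` carries a hydroxy on an aromatic carbon of its outer ring. In a functional assay on PC-3 cells (Homo sapiens) for antiproliferative activity, read by MTT assay, with a stated time of 72 h (on this read-out higher numbers stand for weaker inhibition and lower numbers for stronger inhibition), compound 1 reaches only a limit of the assay, > 100000 nM. Compound 2 `C/C(=N\NC(=O)c1cccc(S(=O)(=O)N2CCOCC2)c1)c1cc(Br)ccc1O` has bromo in that place, and in this assay compound 2 gives 6890 nM. Within the data shown here, this single exchange is the one measured step, an at least 14-fold lower number from compound 1 to compound 2 (1.16 log units; beyond the scatter). Compound 3 `O=C(N/N=C/c1ccccn1)c1cccc(S(=O)(=O)N2CCOCC2)c1` bears pyridin-2-yl on the carbon with a double bond to nitrogen, and in this assay compound 3 gives 88100 nM, the highest of the two plain numbers shown, well above compound 2.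

Compound 4 `COc1ccc(/C=N/NC(=O)c2cccc(S(=O)(=O)N3CCOCC3)c2)c(O)c1` differs from compound 3 in one place: 2-hydroxy-4-methoxyphenyl in place of pyridin-2-yl on a carbon with a double bond to nitrogen. The entering ring resembles the outer rings of compound 1 and compound 2, and the step from compound 1 to compound 2 shows how much a substituent on such a ring can move the number; a hydroxy-bearing ring in compound 1 gave only a limit, while bromo in compound 2 gave the lowest number. For compound 4 the expected step is therefore modest, a 2.0-fold lower number from compound 3 to compound 4 (0.29 log units; within the scatter), a somewhat lower number than compound 3 but far from compound 2. Compound 4 is estimated at 45000 nM, with a range from 12000 nM to 150000 nM.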

Compound 4, half-maximal inhibitory concentration: 5800 nM
For compound 4 the middle estimate is 7.8-fold (0.89 log units) above the measured one; the measured number lies below the stated range.
By their numbers in this assay, from the lowest: compounds 4 and 2 (each within the scatter of the next); then compound 3. At a limit, above all of these: compound 1.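

The ring on the carbon with a double bond to nitrogen turns out to matter a great deal in this assay: exchanging pyridin-2-yl for 2-hydroxy-4-methoxyphenyl gives a 15-fold lower number from compound 3 to compound 4 (1.18 log units; beyond the scatter). Among these compounds, the only step measured before this one changed a substituent on an outer ring that otherwise stayed in place, whereas this step replaces the whole ring, and the number still moves by a large amount. It therefore extends the evidence from a single substituent to the identity of the ring itself, although it remains one exchange between one pair of compounds.

Among the compounds shown here, this single step cannot separate the loss of the ring nitrogen from the arrival of the hydroxy and the methoxy, so it remains open whether an unsubstituted phenyl, a phenyl carrying only one of those two groups, or a ring bearing an amine or a carboxylic acid would give a similar number. The data shown give no measured property of these groups that could explain the size of the step.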